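The compounds below may be only part of what the source reports. "The series", "measured", "known", "first", "only" and "open" are said of these compounds alone.

Working notes on the series

Compound 1 `N#CC1=C(N)Oc2c(c3nc4ccccc4nc3c3ccccc23)C12C(=O)N(Cc1cnnn1-c1ccc(S(N)(=O)=O)cc1)c1ccccc12` carries a 4-sulfamoylphenyl on the aromatic nitrogen of its triazole; in a functional assay on HCT-116 cells (Homo sapiens) for antiproliferative activity, read by MTT assay, with a stated time of 48 h (on this read-out higher numbers stand for weaker inhibition and lower numbers for stronger inhibition), compound 1 gives 31200 nM. Compound 2 `Cc1ccc(Cl)cc1-n1nncc1CN1C(=O)C2(C(C#N)=C(N)Oc3c2c2nc4ccccc4nc2c2ccccc32)c2ccccc21` differs from it only in the aryl on that nitrogen. Compound 2 returns only a limit of the assay, > 50000 nM. The step of an at least 1.6-fold higher number from compound 1 to compound 2 (0.20 log units; that floor lies within the scatter) is therefore a change whose floor is not resolved from repeat scatter. Compound 3 `N#CC1=C(N)Oc2c(N)cc3nc4ccccc4nc3c2C12C(=O)N(Cc1cnnn1-c1ccc([N+](=O)[O-])cc1)c1ccccc12` has an amino group on the shared core and a 4-nitrophenyl on the triazole nitrogen. Compound 3 also returns only a limit, > 50000 nM; its standing among the numbers shown is thus set by the limit of > 50000 nM in this assay, at which 2 of the 3 values shown sit, with no measured number of its own.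

Compound 4 `N#CC1=C(N)Oc2c(N)cc3nc4ccccc4nc3c2C12C(=O)N(Cc1cnnn1-c1ccc(F)c(Cl)c1)c1ccccc12` is the next member. It differs from compound 3 as follows: 3-chloro-4-fluorophenyl in place of 4-nitrophenyl on an aromatic nitrogen. For the measured compounds named here, the only measured step touching the same aryl position is the one from compound 1 to compound 2, which moved toward a weaker value or a limit; no step in this set moved toward a stronger value at that position. Compound 4 is expected to sit at or near the limit, with a step that the limit leaves unreadable from compound 3 to compound 4 as the expected step. The estimate for compound 4 in this assay is 70000 nM, within 25000 nM to 200000 nM.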

Compound 4, half-maximal inhibitory concentration: > 50000 nM
Compound 4: a limit, no number; the forecaster's own chance of this, stated with the estimate: 70%; the middle value lies beyond the limit too.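

For the compounds shown here, compound 4 returns only a limit in this assay, > 50000 nM, and compound 3 is likewise recorded only as a limit, so no step between these two compounds can be read. The compounds shown leave open how 3-chloro-4-fluorophenyl and 4-nitrophenyl compare, as both results rest on the same boundary: the limit of > 50000 nM in this assay, at which 3 of the 4 values shown sit.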